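A Five-Membered Heteroaryl Returns at the Saturated Carbon

The source may hold more compounds than are shown below. What is called first, only, known or untested is meant among the compounds shown, and "the series" means these compounds.

Measured compounds:
Compound 1, `CN1C(=O)[C@@]2(c3ccccc31)N(C)C[C@@H](c1ccco1)[C@@]21Cc2ccccc2C1=O`: in a functional assay on the whole organism (strain Wister albino) for inhibition, with Rattus norvegicus as the target, read by paw edema, with stated times of 1 h and 3 h, at a dose of 50 mg/kg by the intraperitoneal route (a lower number here means less inhibition, a higher number more inhibition at the dose given (going by the name of the read-out)), compound 1 gives 17.5%.
Compound 2, `CN1C(=O)[C@@]2(c3ccccc31)N(C)C[C@@H](c1ccc(F)cc1)[C@@]21Cc2ccccc2C1=O`: in this assay compound 2 gives 26.9%.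
Compound 3, `Cc1ccc([C@@H]2CN(C)[C@]3(C(=O)N(C)c4ccccc43)[C@]23Cc2ccccc2C3=O)cc1`: in this assay compound 3 gives 6.4%.

Compound 3 stands lowest of the three in this assay. Its nearest neighbour is compound 1, with a number 11.1 percentage points lower from compound 1 to compound 3 (beyond the scatter); furthest is compound 2, with a number 20.5 percentage points lower from compound 2 to compound 3 (beyond the scatter). The other measured step, a number 9.4 percentage points higher from compound 1 to compound 2 (within the scatter), lies within the scatter.

Compound 4, `CN1C(=O)[C@@]2(c3ccccc31)N(C)C[C@@H](c1cccs1)[C@@]21Cc2ccccc2C1=O`, has not yet been measured in this assay. It differs from compound 3 in one place: thiophen-2-yl in place of 4-methylphenyl on a saturated ring carbon.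

The step that bears most on this change is a number 11.1 percentage points lower from compound 1 to compound 3 (beyond the scatter), since that step replaced a five-membered heteroaryl with 4-methylphenyl at the same saturated ring carbon and lowered the read-out modestly; the change to compound 4 runs the other way, putting a five-membered heteroaryl back. Compound 4 is therefore expected to read higher than compound 3 in this assay by roughly the size of that step, about a number 10.6 percentage points higher from compound 3 to compound 4 (beyond the scatter), though how thiophen-2-yl compares with furan-2-yl is not known from these compounds. For compound 4 the estimate in this assay is 17%, with a range from 8% to 28%.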

Compound 4, a percentage reported as inhibition, in the whole organism at one dose (the size of the read-out at that dose, not a potency): 9.1%
Compound 4: the middle estimate sits 7.9 percentage points above what was measured; the range from low to high includes it.
By their numbers in this assay, from the lowest: compounds 3, 4, 1 and 2 (each within the scatter of the next, the first and the last beyond it).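

In this assay, putting a five-membered heteroaryl back on this saturated ring carbon did not set compound 4 apart from the six-membered aryl of compound 3: the change to thiophen-2-yl gives a number 2.7 percentage points higher from compound 3 to compound 4 (within the scatter), and the exchange of furan-2-yl for thiophen-2-yl gives a number 8.4 percentage points lower from compound 1 to compound 4 (within the scatter). Within the data shown here, only the step from 4-fluorophenyl is clear, at a number 17.8 percentage points lower from compound 2 to compound 4 (beyond the scatter), so ring size alone does not sort this position: compound 3 and compound 2 both carry a six-membered aromatic ring, yet only compound 2 stands clear of compound 4. Nothing shown here accounts for these differences. As far as these compounds go, whether an aminomethyl group or a carboxylic acid on the thiophen-2-yl ring would change the read-out in this assay remains open.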